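Replacing a cyanopiperidine with a quinoline: expected solubility loss

A few compounds are considered here, and "the series" means these few. Any claim that something is new, unique, unknown or untested is made for them only; others in the source may bear on it.

Measured so far:
compound 1, `OCC1CCN(c2nccnc2OC2CN(c3ncc4ccccc4n3)C2)CC1`: 174000 nM
compound 2, `OCC1CCN(c2cccnc2OC2CN(c3ccc4ccccc4n3)C2)CC1`: 189000 nM
compound 3, `N#CC1CCN(c2nccnc2OC2CN(c3ccc4ccccc4n3)C2)CC1`: 66000 nM

These three compounds share a core and were tested in a physicochemical assay for solubility, in phosphate buffer, at pH 7.4; on this read-out higher numbers stand for higher solubility and lower numbers for lower solubility. Compound 3 stands lowest of the three numbers; compound 1, the nearest, and compound 2, the furthest, both lie higher by more than the usual scatter, so compound 3 is the least soluble of the three.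

The next compound, compound 4, is `c1ccc2ncc(-c3nccnc3OC3CN(c4ccc5ccccc5n4)C3)cc2c1`; it has not yet been tested in this assay. It differs from compound 3 in one place: quinolin-3-yl in place of 4-cyanopiperidin-1-yl on an aromatic carbon. A six-membered non-aromatic ring bearing a nitrile and two hydrogen-bond acceptors leaves, and a pair of fused aromatic rings with a single hydrogen-bond acceptor enters, at a position ortho to a large group on the shared core.

Among the measured compounds shown here, no measured pair shows this kind of exchange, so the size of the step is uncertain. Still, a drop well beyond the scatter is expected, and the step from compound 3 to compound 4 is estimated as a 17-fold lower number from compound 3 to compound 4 (1.22 log units; beyond the scatter). On that basis, compound 4 is expected to give about 4000 nM in this assay, with a likely range from 800 nM to 20000 nM.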

Compound 4, solubility: < 1000 nM
Compound 4 gave a limit, no number; the forecaster's own chance of this, stated with the estimate: 10%; middle value at least 4.0-fold (0.60 log units) from the limit.
By their numbers in this assay, from the lowest: compound 3; then compounds 1 and 2 (each within the scatter of the next). At a limit, below all of these: compound 4.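

Among the compounds shown here, this is the first step in the set that changes only one place, so the group on this aromatic carbon, next to the ring nitrogen and ortho to a large group, can now be read directly. Putting quinolin-3-yl in place of 4-cyanopiperidin-1-yl gives an at least 66-fold lower number from compound 3 to compound 4 (1.81 log units; beyond the scatter) in this assay, and compound 4 gives < 1000 nM, which is a limit and not a number. The read-out therefore depends strongly on the group at this position, and this exchange of a non-aromatic ring for a pair of fused aromatic rings takes the value to the end of the range the assay reports: the limit of < 1000 nM in this assay, at which 1 of the 4 values shown sits.

With only a limit for compound 4, the full size of the step cannot be read, and this single exchange cannot separate the loss of the nitrile from the loss of the non-aromatic ring or the arrival of the fused aromatic rings. The compounds shown also leave open how a non-aromatic ring carrying an amine or a carboxylic acid would read at this position.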